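A few compounds are considered here, and "the series" means these few. Any claim that something is new, unique, unknown or untested is made for them only; others in the source may bear on it.

Measured so far:
Compound 1 `Nc1ccccc1COc1ccc(OCCOCCNC2CCCC2)cc1` gives 14000 nM
Compound 2 `Cc1ccc(COc2ccc(OCCOCCNC3CCCC3)cc2)cc1` gives 17200 nM

In a functional assay on SK-OV-3 cells (Homo sapiens) for inhibition, read by CCK-8 assay, with a stated time of 70 h (a lower number here means a stronger inhibitor, a higher number a weaker inhibitor), compound 2 gives 17200 nM and lies within the scatter of compound 1. Compound 3 `COC(=O)c1ccccc1COc1ccc(OCCOCCNC2CCCC2)cc1` has not been measured yet. It carries 2-(methoxycarbonyl)phenyl in place of 4-methylphenyl on a saturated chain carbon bound to an oxygen on an aromatic ring. Within the data shown here, one measured step bears on this place, where 2-aminophenyl gave way to 4-methylphenyl (a 1.2-fold higher number from compound 1 to compound 2 (0.09 log units; within the scatter)). Among the measured compounds shown here, that step stayed within the scatter, but no measured compound carries a methoxycarbonyl group, so the guide is thin. No step beyond the scatter is expected, and the expected step is small (a 1.1-fold lower number from compound 2 to compound 3 (0.06 log units; within the scatter)). Compound 3 is expected at 15000 nM (estimated range 6000 nM to 35000 nM).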

Compound 3, half-maximal inhibitory concentration: > 100000 nM
Compound 3 ended at the assay's limit; the forecaster's own chance of this, stated with the estimate: 10%; middle value at least 6.6-fold (0.82 log units) away from the limit.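

In this assay compound 3 gives > 100000 nM and this is a limit of the assay, not a number. The group on the saturated chain carbon bound to an oxygen on an aromatic ring can therefore matter: the earlier change at this place stayed within the scatter, whereas 2-(methoxycarbonyl)phenyl in place of 4-methylphenyl gives an at least 5.8-fold higher number from compound 2 to compound 3 (0.76 log units; beyond the scatter) and moves the result beyond it. Methoxycarbonyl in place of amino on an aromatic carbon gives an at least 7.1-fold higher number from compound 1 to compound 3 (0.85 log units; beyond the scatter) and shows that these two groups are not interchangeable on this ring.

As far as these compounds go, how much weaker compound 3 really is stays unknown, as its value is only a limit. A carboxylic acid or an amide in place of the methoxycarbonyl would show whether this loss belongs to the methyl ester alone or extends to other carbonyl groups.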